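Replacing the chloro on the core of compound 1

A few compounds are considered here, and "the series" means these few. Any claim that something is new, unique, unknown or untested is made for them only; others in the source may bear on it.

The series shares the core of compound 1, `Fc1cccc(F)c1Cn1c(-c2c(F)cccc2F)nc2c(Cl)cccc21`. Going by the values given here, in a toxicity assay on CCRF-CEM cells (Homo sapiens) for cytotoxicity (on this read-out lower numbers stand for higher toxicity in this test and higher numbers for lower toxicity in this test), compound 1 gives 30.4 uM, the only number in hand. Compound 2, `NC(=O)c1cccc2c1nc(-c1c(F)cccc1F)n2Cc1c(F)cccc1F`, carries carbamoyl in place of chloro on an aromatic carbon. In this assay compound 2 reaches only a limit, > 100 uM. The step of an at least 3.2-fold higher number from compound 1 to compound 2 (0.51 log units; beyond the scatter) is bounded from one side only because the limit of > 100 uM in this assay, at which 1 of the 2 values shown sits, caps what the test can report.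

Compound 3, `NCc1cccc2c1nc(-c1c(F)cccc1F)n2Cc1c(F)cccc1F`, is not yet measured. It differs from compound 1 as follows: aminomethyl in place of chloro on an aromatic carbon. Among the compounds with values here, the one measured step that bears on it, the exchange of chloro for carbamoyl, gave at least a modest move toward a higher number. A step of similar direction is expected for compound 3, a 2.6-fold higher number from compound 1 to compound 3 (0.42 log units; beyond the scatter), and a limit rather than a number is a real possibility. Compound 3 is estimated at 80 uM, within 30 uM to 200 uM.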

Compound 3, half-maximal toxic concentration: 49.3 uM
The estimate for compound 3 lay 1.6-fold (0.21 log units) above the measured number; the measured number falls inside the stated range.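

In this assay, aminomethyl in place of chloro gives a 1.6-fold higher number from compound 1 to compound 3 (0.21 log units; within the scatter), so the clear shift seen with carbamoyl at this aromatic carbon does not extend to every group tried there. Between the two replacing groups the reading is an at least 2.0-fold lower number from compound 2 to compound 3 (0.30 log units; that floor lies within the scatter), which settles no order between carbamoyl and aminomethyl. That step is only a floor because compound 2 stands at a limit, not a number: the limit of > 100 uM in this assay, at which 1 of the 3 values shown sits.

The compounds shown leave open how a carboxylic acid, a plain hydrogen or a longer chain such as aminoethyl would read at this position. They also leave open whether the shift with carbamoyl belongs to the carbonyl of the amide or to the group as a whole, which a methyl ketone or an N-methyl amide could help separate.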